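The source may hold more compounds than are shown below. What is called first, only, known or untested is meant among the compounds shown, and "the series" means these compounds.

In a functional assay for binding affinity to metabotropic glutamate receptor 2 (Homo sapiens), read by GTPgammaS binding (on this read-out higher numbers stand for an effect only at larger amounts of compound and lower numbers for an effect already at smaller amounts), compound 1 `Cc1c(OCCCCOc2cccc(F)c2F)ccc(C(=O)CC(C)C)c1O` gives 384 nM. Compound 2 `Cc1c(OCCCCOc2cccnc2)ccc(C(=O)CC(C)C)c1O` gives 1720 nM. Compound 3 `Cc1c(OCCCCSc2ccccn2)ccc(C(=O)CC(C)C)c1O` gives 1530 nM.

Compound 3 stands second highest of the three numbers: its step from compound 2, a 1.1-fold lower number from compound 2 to compound 3 (0.05 log units; within the scatter), lies within the scatter, whereas a 4.0-fold higher number from compound 1 to compound 3 (0.60 log units; beyond the scatter) sets it apart from compound 1. Compound 4 `Cc1c(OCCCCSc2ccncc2)ccc(C(=O)CC(C)C)c1O` differs from compound 3 by pyridin-4-yl in place of pyridin-2-yl on a sulfur. The step that bears on this change is a 1.1-fold lower number from compound 2 to compound 3 (0.05 log units; within the scatter), where exchanging one pyridyl group and its linker for another left the number within the scatter. The larger steps of a 4.5-fold higher number from compound 1 to compound 2 (0.65 log units; beyond the scatter) and a 4.0-fold higher number from compound 1 to compound 3 (0.60 log units; beyond the scatter) concern replacing the difluorophenyl group and do not speak to a change between pyridyl groups. Compound 4 is therefore expected to show a 1.0-fold lower number from compound 3 to compound 4 (0.01 log units; within the scatter), that is no step beyond the scatter. The estimate for compound 4 is 1500 nM, with a range from 600 nM to 4000 nM.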

Compound 4, half-maximal effective concentration: 340 nM
Beside the measured number, compound 4's estimate is 4.4-fold (0.64 log units) above it; measured number outside the range, below it.
By their numbers in this assay, from the lowest: compounds 4 and 1 (each within the scatter of the next); then compounds 3 and 2 (each within the scatter of the next).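

In this assay, among these compounds, the exchange of pyridin-2-yl for pyridin-4-yl on a sulfur is not neutral: the two groups hold the same atoms, yet the result is a 4.5-fold lower number from compound 3 to compound 4 (0.65 log units; beyond the scatter) and the earlier exchange between pyridyl groups gave no such step. The same group also gives a 5.1-fold lower number from compound 2 to compound 4 (0.70 log units; beyond the scatter) while a 1.1-fold lower number from compound 1 to compound 4 (0.05 log units; within the scatter) leaves it level with the difluorophenoxy compound, so a pyridine on this chain does not always bring the higher number, although compounds 2 and 3 keep it. Nothing shown here explains this difference. Still open, as far as these compounds go, is whether the step holds with the pyridin-3-yl group on the sulfur or with the pyridin-4-yl group on an oxygen. Also open, from the compounds shown here alone, is what an amine on the pyridine ring or a longer chain would do.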